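This account rests on a few compounds, and the source may have more. Where it says the series, first, only, none or still open, it means among the compounds named here.

Values in a functional assay on microsomes for inhibition, with a stated time of 1 h (a higher number here means a weaker inhibitor, a lower number a stronger inhibitor), so far are as follows.

- compound 1 (`CCOC(=O)c1cnn(-c2nc(-c3ccccc3F)c(C#N)c(=O)n2C)c1N`) gives 94 ug/mL
- compound 2 (`CSc1nc(-c2ccco2)c(C#N)c(=O)n1C`) gives 90 ug/mL
- compound 3 (`CSc1nc(-c2ccccc2O)c(C#N)c(=O)n1C`) gives 44 ug/mL

Compound 3 holds the lowest number of the three, and compound 1 and compound 2 both stand above it by gaps beyond the scatter. Compound 4 (`Cn1c(NN)nc(-c2ccccc2O)c(C#N)c1=O`) carries aminoamino in place of methylsulfanyl on an aromatic carbon. Among the compounds with values here, no measured pair shows this exchange. The spread in this assay is narrow, from compound 3 at 44 ug/mL to compound 1 at 94 ug/mL even with a different group on that carbon. The expected change is none beyond the scatter, an estimated 1.1-fold lower number from compound 3 to compound 4 (0.04 log units; within the scatter) with no firm direction. The estimate for compound 4 is 40 ug/mL within a range of 15 ug/mL to 100 ug/mL on this thin evidence.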

Compound 4, half-maximal inhibitory concentration: 34 ug/mL
Compound 4: middle estimate off by 1.2-fold (0.07 log units), on the high side; the measured number falls inside the stated range.
By their numbers in this assay, from the lowest: compounds 4 and 3 (each within the scatter of the next); then compounds 2 and 1 (each within the scatter of the next).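

In this assay, within the data shown here, aminoamino in place of methylsulfanyl on the aromatic carbon between two ring nitrogen atoms gives a 1.3-fold lower number from compound 3 to compound 4 (0.11 log units; within the scatter), the first direct reading of a change at this position. Within the scatter, compound 3 and compound 4 cannot be told apart, so this exchange, which brings in hydrogen-bond donors, leaves the number unresolved from that of the methylsulfanyl parent. Nothing available bears on the reason for this result.

Going by these compounds, whether a simple amine, a methoxy group or a longer alkyl chain on this carbon would read differently remains open. Also open, on these data alone, is whether the same exchange reads alike on the core of compound 2.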